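The source may report more compounds than this note shows. Statements on the series, on what has been measured and on what is new or still open speak of the compounds shown alone.

Within the data shown here, compound 1 `Fc1cccc(-c2nc(Nc3ccccc3)c3cc(F)ccc3n2)c1` is the only member of this set with a numerical result: in a functional assay on HT29-AK cells (Homo sapiens) for cytotoxicity, read by MTT assay, with a stated time of 48 h (on this read-out lower numbers stand for stronger inhibition and higher numbers for weaker inhibition), compound 1 gives 48300 nM. Compound 2 `COc1ccccc1Nc1nc(-c2cccc(F)c2)nc2ccc(F)cc12` carries a methoxy in place of hydrogen on an aromatic carbon, and in this assay compound 2 reaches only the assay limit of > 50000 nM. Compound 3 `Fc1cccc(-c2nc(Nc3cccc(Br)c3)c3cc(F)ccc3n2)c1` carries a bromo in place of hydrogen on an aromatic carbon, and in this assay compound 3 likewise stops at the limit of > 50000 nM. Thus compound 1 sits lowest of the three on the numbers shown, yet the two steps away from it, an at least 1.0-fold higher number from compound 1 to compound 2 (0.01 log units; that floor lies within the scatter) and an at least 1.0-fold higher number from compound 1 to compound 3 (0.01 log units; that floor lies within the scatter), are each no more than a floor that stays within the scatter, and a step that the two limits leave unreadable from compound 2 to compound 3 cannot be read at all, because the limit of > 50000 nM in this assay, at which 2 of the 3 values shown sit, applies to both ends of it.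

Compound 4 `Fc1cccc(-c2nc(Nc3ccccc3Br)c3cc(F)ccc3n2)c1` is the remaining analogue. Relative to compound 1 the change is bromo in place of hydrogen on an aromatic carbon. The two measured steps that bear on it, both substitutions of hydrogen on the anilino ring, moved the read-out only to the limit, so no step beyond the scatter is expected in this assay, with a real chance that compound 4 also reports only a limit. The expected step is a 1.1-fold higher number from compound 1 to compound 4 (0.06 log units; within the scatter). Compound 4 is therefore estimated at 55000 nM, with a range from 30000 nM to 120000 nM.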

Compound 4, half-maximal inhibitory concentration: > 50000 nM
Compound 4: only a limit was reported (the forecaster's own chance of this, stated with the estimate: 60%); the middle value does not contradict the limit.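

In this assay, the change from phenyl to 2-bromophenyl, which sets a bromo ortho to a large group, gives an at least 1.0-fold higher number from compound 1 to compound 4 (0.01 log units; that floor lies within the scatter). The earlier compounds had shown the same floor for the 3-bromophenyl and 2-methoxyphenyl groups, so a bromo at this new place also yields a limit and not a number, and the floor shows no change beyond the scatter. The steps among compound 2, compound 3 and compound 4 cannot be read, so neither the two places of the bromo nor bromo against methoxy can be ranked, and the reason lies in the shared ceiling of the read-out: the limit of > 50000 nM in this assay, at which 3 of the 4 values shown sit.

The compounds shown leave open whether any group on the anilino ring can bring the read-out in this assay to a number clearly lower than that of compound 1. An amine or a carboxylic acid at these places might answer this, and so might a change elsewhere on the shared core, such as replacing either fluoro.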